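A Smaller Tail on the Sulfur: Compound 2 to Compound 4

The source may hold more compounds than are shown below. What is called first, only, known or untested is meant among the compounds shown, and "the series" means these compounds.

Compound 2 `Cc1cc(Nc2cc(-c3ccccc3)[nH]n2)n2nc(SCCCc3ccccc3)nc2n1` is the only one of the three measured compounds with an actual number in a functional assay on PC-9 cells (Homo sapiens) for inhibition, read by MTT assay, with a stated time of 72 h; a lower number here means a stronger inhibitor, a higher number a weaker inhibitor: compound 2 gives 5030 nM. Compound 1 `CCCCCc1c(C)nc2nc(SCc3ccc(Cl)cc3)nn2c1Nc1cc(-c2ccccc2)[nH]n1` reaches only the limit of the assay, > 50000 nM. Compound 3 `Cc1nc2nc(SCc3ccc(Cl)cc3)nn2c(Nc2cc(-c3ccccc3)[nH]n2)c1C` likewise stops at the limit, > 50000 nM. The step that the two limits leave unreadable from compound 1 to compound 3 therefore cannot be read. Compound 4 `Cc1cc(Nc2cc(-c3ccccc3)[nH]n2)n2nc(SCC3CC3)nc2n1` differs from compound 2 by cyclopropyl in place of phenethyl on a saturated chain carbon bound to a sulfur. No measured step touches this part of the molecule, so nothing shown says how large a change to expect in this assay, or in which direction. Taking compound 2 as the only anchor, compound 4 is expected to give about 10000 nM, somewhere between 2500 nM and 40000 nM. The step of a 2.0-fold higher number from compound 2 to compound 4 (0.30 log units; within the scatter) is an estimate only.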

Compound 4, half-maximal inhibitory concentration: > 50000 nM
Compound 4: a limit, no number (the forecaster's own chance of this, stated with the estimate: 25%); middle value at least 5.0-fold (0.69 log units) away from the limit.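

In this assay, among these compounds, there is an at least 9.9-fold higher number from compound 2 to compound 4 (0.99 log units; beyond the scatter) when cyclopropyl replaces phenethyl, the first readable change on a saturated chain carbon bound to a sulfur. This place in the molecule therefore affects the result, and the phenethyl-bearing compound 2 is the one that keeps a measurable number. On these data alone, compound 4 gives only a limit, so the full size of this step stays unknown: the limit of > 50000 nM in this assay, at which 3 of the 4 values shown sit.

As far as these compounds go, with only these two groups compared, it remains open whether the phenyl ring or the chain length matters more. A plain butyl chain, or a chain ending in an amine, would help separate the two.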